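Trifluoromethylphenyl in place of difluorophenyl: an aryl swap

The compounds below may be only part of what the source reports. "The series", "measured", "known", "first", "only" and "open" are said of these compounds alone.

Compound 1 `Cn1cc(-c2ccc(NC(=O)c3cn(CC4CCOCC4)cc(-c4ccc(F)cc4F)c3=O)cc2)c2c(N)ncnc21` is one of three measured compounds built on a shared core. In an assay on isolated protein for inhibition of tyrosine-protein kinase receptor UFO (Homo sapiens), read by ELISA (a higher number here means a weaker inhibitor, a lower number a stronger inhibitor), compound 1 gives 0.8 nM, the second highest of the three numbers. Compound 2 `Cn1cc(-c2ccc(NC(=O)c3cn(CC4CCOCC4)cc(-c4ccc(F)cc4)c3=O)c(F)c2)c2c(N)ncnc21` gives 0.2 nM in this assay, a lower number than compound 1 by a margin beyond the scatter, while compound 3 `Cc1nc(N)c2c(-c3ccc(NC(=O)c4cn(CC5CCOCC5)cc(-c5ccc(F)cc5)c4=O)cc3)cn(C)c2n1` gives 5.1 nM, a higher number than compound 1 and likewise beyond the scatter. Compound 4 `Cn1cc(-c2ccc(NC(=O)c3cn(CC4CCOCC4)cc(-c4ccc(C(F)(F)F)cc4)c3=O)cc2)c2c(N)ncnc21` has not yet been measured. It differs from compound 1 in a single place: 4-(trifluoromethyl)phenyl in place of 2,4-difluorophenyl on an aromatic carbon. For the measured compounds named here, no measured pair shows this same change, so its direction cannot be read from the data. Neither compound 2 nor compound 3 carries a trifluoromethyl group, and the entering group counts more heavy atoms than the one it replaces. A modest rise in the number is expected for compound 4, a 2.5-fold higher number from compound 1 to compound 4 (0.40 log units; beyond the scatter), though a result within the scatter of compound 1 would not surprise. Compound 4 is expected to give about 2 nM in this assay, within a range of 0.5 nM to 8 nM.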

Compound 4, half-maximal inhibitory concentration: 0.4 nM
The estimate for compound 4 lay 5.0-fold (0.70 log units) above the measured number, and the stated range ends above it.
By their numbers in this assay, from the lowest: compounds 2, 4 and 1 (each within the scatter of the next, the first and the last beyond it); then compound 3.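

In this assay, for the compounds shown here, 4-(trifluoromethyl)phenyl in place of 2,4-difluorophenyl gives a 2.0-fold lower number from compound 1 to compound 4 (0.30 log units; within the scatter) and so gives the first reading of any change at this position, on an aromatic carbon of a six-membered aromatic ring with 1 nitrogen. At this resolution the assay does not separate the two groups, even though the entering group has 10 heavy atoms against 8 and carries trifluoromethyl in place of two ring fluorines. No measurement among the data bears on why the two groups read alike.

The compounds shown leave open whether this position accepts a group of another kind, such as a carboxylic acid, an amine or a longer alkyl chain, as it accepts these two aryl groups. They also leave open whether the same swap would read alike on the other variations of the shared core.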